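The source may hold more compounds than are shown below. What is called first, only, known or untested is meant among the compounds shown, and "the series" means these compounds.

Working notes on the series. Two compounds carry numbers in an assay on isolated protein for activation of Nicotinamide phosphoribosyltransferase (Homo sapiens); a lower number here means that less compound is needed, a higher number that more compound is needed for the effect. Compound 1 `O=C(NCc1ccncc1)Nc1ccc(S(=O)(=O)Nc2ccccc2)cc1` gives 410 nM, the lowest of the two. Compound 2 `CCOC(=O)c1ccc(NC(=O)NCc2cnco2)cc1`, built on the same urea but with a different ring on each side of it, gives 6900 nM, a higher number that lies beyond the usual scatter. Among the measured compounds shown here, no step between compounds differing in a single place is available, so this pair shows only that compound 1 sits at the more potent end of what is known. Compound 3 `CN(C)S(=O)(=O)c1ccc(NC(=O)NCc2ccncc2)cc1` is the next point; it differs from compound 1 in one place: dimethylamino in place of anilino on a sulfonyl sulfur The sulfonyl sulfur, the urea and the pyridylmethyl arm are kept. For the measured compounds named here, with no measured step of this kind to lean on, the expectation for compound 3 is a modest loss, a 2.9-fold higher number from compound 1 to compound 3 (0.47 log units; beyond the scatter), close to the edge of the scatter. Compound 3 is accordingly estimated at 1200 nM, within a range of 300 nM to 6000 nM.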

Compound 3, half-maximal effective concentration: 3110 nM
Estimate against measurement, compound 3: 2.6-fold (0.41 log units) below, and the stated range covers the measured number.
By their numbers in this assay, from the lowest: compound 1; then compound 3; then compound 2.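

Among the compounds shown here, this is the first step that changes one place: on a sulfonyl sulfur whose other neighbour is an aromatic carbon, dimethylamino in place of anilino gives a 7.6-fold higher number from compound 1 to compound 3 (0.88 log units; beyond the scatter) in this assay. The number at this position therefore depends on the group on the sulfur, and the step lies beyond the scatter. The change removes the six-membered aromatic ring of carbon and the hydrogen-bond donor of anilino together, and no measured evidence accounts for the rise in the number.

The step cannot separate the ring from the donor. Open, from the compounds shown here alone, is whether methylamino or cyclohexylamino on the sulfonyl sulfur would give a number closer to that of compound 1 or to that of compound 3.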